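Fluoro on the pendant phenyl in two acetylindole pairs

A few compounds are considered here, and "the series" means these few. Any claim that something is new, unique, unknown or untested is made for them only; others in the source may bear on it.

Compound 1 `COc1ccc(-c2cc3cc(-c4ccccc4)cc(C(C)=O)c3[nH]2)cc1` and compound 2 `COc1ccc(-c2cc3cc(-c4ccc(F)cc4)cc(C(C)=O)c3[nH]2)cc1` share a core and differ by fluoro in place of hydrogen on an aromatic carbon. In a functional assay on MCF7 cells (Homo sapiens) for cytotoxicity, read by MTT assay, with a stated time of 2 days, tested at 1 uM (a higher number here means a weaker effect of the compound at the concentration tested, a lower number a stronger effect), compound 1 gives 78.1% and compound 2 gives 96.4%, so that a number 18.3 percentage points higher from compound 1 to compound 2 (beyond the scatter). Compound 3 `CC(=O)c1cc(/C=C/c2ccccc2)cc2cc(-c3ccc(F)cc3)[nH]c12` carries the phenyl on a 2-phenylethenyl arm; the difference between the core of compound 3 and that of compound 1 is not broken down here. In this assay compound 3 gives 86.9%. Compound 4 `CC(=O)c1cc(/C=C/c2ccc(F)cc2)cc2cc(-c3ccc(F)cc3)[nH]c12`, not yet measured, differs from compound 3 by fluoro in place of hydrogen on an aromatic carbon, the same change as from compound 1 to compound 2, again para to a large group. Because a number 18.3 percentage points higher from compound 1 to compound 2 (beyond the scatter) went toward a weaker effect, a step of similar direction is expected, a number 6.1 percentage points higher from compound 3 to compound 4 (within the scatter), though smaller since compound 3 already sits high. Compound 4 is estimated at 93%, between 80% and 103%.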

Compound 4, a percentage reported as activity, at one concentration (the size of the read-out at that concentration, not a potency): 82%
Compound 4: middle estimate off by 11 percentage points, on the high side, within the range that was stated.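

In this assay, fluoro in place of hydrogen on the phenyl of the 2-phenylethenyl arm gives a number 4.9 percentage points lower from compound 3 to compound 4 (within the scatter). The step seen on the core of compound 1 therefore does not carry over to this core: the same change on two cores in this assay, a number 18.3 percentage points higher (beyond the scatter) from compound 1 to compound 2 and a number 4.9 percentage points lower (within the scatter) from compound 3 to compound 4, 23.2 percentage points apart, beyond the scatter of two such steps. Going by these compounds alone, this shows that the step from this change depends on the core across these two pairs, but with only two pairs it does not show why, or what the change would do on any further core.

On these data alone, it remains open whether chloro, an amine or a carboxylic acid in the same place would behave like fluoro on either core. Each result is also a read-out at one concentration, so it speaks only of a stronger or weaker effect at that concentration.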